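From 4-cyanophenyl to quinolin-5-yl on a shared core

The source may report more compounds than this note shows. Statements on the series, on what has been measured and on what is new or still open speak of the compounds shown alone.

Compound 1 `C=CS(=O)(=O)N1CCN(c2ncnc3sc(-c4ccccc4)cc23)CC1` gives 54200 nM
Compound 2 `C=CS(=O)(=O)N1CCN(c2ncnc3sc(-c4ccc(OC)cc4)cc23)CC1` gives 29900 nM
Compound 3 `C=CS(=O)(=O)N1CCN(c2ncnc3sc(-c4ccc(C#N)cc4)cc23)CC1` gives 8050 nM

These values come from a functional assay on MDA-MB-231 cells (Homo sapiens) for antiproliferative activity, read by MTT assay, with a stated time of 48 h (on this read-out lower numbers stand for stronger inhibition and higher numbers for weaker inhibition), and compound 3 holds the lowest of the three numbers. The steps that reach it are a 6.7-fold lower number from compound 1 to compound 3 (0.83 log units; beyond the scatter) and a 3.7-fold lower number from compound 2 to compound 3 (0.57 log units; beyond the scatter) and the remaining step is a 1.8-fold lower number from compound 1 to compound 2 (0.26 log units; within the scatter). Compound 4 `C=CS(=O)(=O)N1CCN(c2ncnc3sc(-c4cccc5ncccc45)cc23)CC1` awaits measurement. The change is quinolin-5-yl in place of 4-cyanophenyl on an aromatic carbon and in words it is quinolin-5-yl in place of 4-cyanophenyl on an aromatic carbon. Going by the values given here, no measured step exchanges the whole aromatic group, so the evidence is indirect. Compound 3 stands apart from compound 1 by a 6.7-fold lower number from compound 1 to compound 3 (0.83 log units; beyond the scatter) and compound 4 no longer carries the cyano group, so part of that step is expected to be lost. The expected change is a 2.1-fold higher number from compound 3 to compound 4 (0.32 log units; beyond the scatter) and this remains a modest estimate with wide uncertainty. The estimate for compound 4 is 17000 nM with an expected range from 5000 nM to 50000 nM in this assay.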

Compound 4, half-maximal inhibitory concentration: 21000 nM
The estimate for compound 4 lay 1.2-fold (0.09 log units) below the measured number; measured number inside the range.
By their numbers in this assay, from the lowest: compound 3; then compounds 4, 2 and 1 (each within the scatter of the next, the first and the last beyond it).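

In this assay, quinolin-5-yl in place of 4-cyanophenyl on the aromatic carbon next to the ring sulfur gives a 2.6-fold higher number from compound 3 to compound 4 (0.42 log units; beyond the scatter) and so leaves compound 3 with the lowest number of the four. The two-ring group still compares well with plain phenyl, with a 2.6-fold lower number from compound 1 to compound 4 (0.41 log units; beyond the scatter) as the step, which shows that this position accepts a fused aromatic group without a return to the level of compound 1. The step of a 1.4-fold lower number from compound 2 to compound 4 (0.15 log units; within the scatter) lies within the scatter, so quinolin-5-yl and 4-methoxyphenyl cannot be told apart here.

As far as these compounds go, whether an amine or a carboxylic acid on the phenyl ring would match the nitrile remains open, as does the role of the quinoline ring nitrogen. No available data explain these differences.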